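Changing the group on nitrogen in compound 2

The source may report more compounds than this note shows. Statements on the series, on what has been measured and on what is new or still open speak of the compounds shown alone.

In a functional assay on HT-29 cells (Homo sapiens) for inhibition, read by sulforhodamine B assay, with a stated time of 48 h (a lower number here means a stronger inhibitor of growth, a higher number a weaker inhibitor of growth), compound 2 `c1ccc(Oc2cccc(NC3=NCCO3)c2)cc1` stands in the middle with 5500 nM (compound 1 `c1cc(NC2=NCCO2)cc(OC2CCCC2)c1` lies higher at 52200 nM and compound 3 `c1ccc(COc2cccc(NC3=NCCO3)c2)cc1` lies lower at 800 nM). Compound 4 `O=C(CCl)NC(=O)Nc1cccc(Oc2ccccc2)c1` keeps the phenyl on an oxygen but changes the group on a nitrogen on an aromatic ring a group of 7 heavy atoms (3 carbon, 1 nitrogen, 2 oxygen, 1 chlorine; no ring) in place of a group of 5 heavy atoms (3 carbon, 1 nitrogen, 1 oxygen; one five-membered non-aromatic ring with 2 hetero atoms), on a nitrogen on an aromatic ring so that an open ((chloromethyl)carbonyl)carbamoyl group replaces the five-membered non-aromatic ring. Within the data shown here, the only measured step is a 9.5-fold lower number from compound 1 to compound 2 (0.98 log units; beyond the scatter) and it is modest. That step concerns the group on the oxygen, so no measurement covers the change on the nitrogen, and its size serves only as a rough guide to how far one swap can move the numbers here. A smaller step toward a lower number is therefore expected, though with little certainty about its direction. On these data alone, the estimated step is a 2.2-fold lower number from compound 2 to compound 4 (0.34 log units; beyond the scatter) and it remains untested. Compound 4 is expected at 2500 nM with an estimated range from 500 nM to 12000 nM until it is measured.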

Compound 4, concentration for 50% growth inhibition: 5200 nM
Estimate against measurement, compound 4: 2.1-fold (0.32 log units) below, within the range that was stated.
By their numbers in this assay, from the lowest: compound 3; then compounds 4 and 2 (each within the scatter of the next); then compound 1.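

In this assay, two very different groups on the nitrogen on the aromatic ring cannot be told apart: a 1.1-fold lower number from compound 2 to compound 4 (0.02 log units; within the scatter), so the open ((chloromethyl)carbonyl)carbamoyl group and the five-membered non-aromatic ring read alike. Among these compounds, the earlier compounds showed only that the group on the oxygen can move the number, as in a 9.5-fold lower number from compound 1 to compound 2 (0.98 log units; beyond the scatter); this pair adds that, at the nitrogen, a ring can give way to an open chain carrying a chlorine with no readable difference. Nothing available here explains why these two groups read alike.

The compounds shown do not separate the part of the chlorine from that of the open chain, which a simple acetyl group on the same nitrogen could address. On these data alone, it also remains open whether the open group would read alike on the core of compound 3.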